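Vinyl for Methoxy on the Aryl Ring of Compound 1

The compounds below may be only part of what the source reports. "The series", "measured", "known", "first", "only" and "open" are said of these compounds alone.

Of the compounds shown here, three of one shared core have so far been tested in a functional assay (muscle tissue) with Cavia porcellus as the target; a lower number here means that less compound is needed, a higher number that more compound is needed for the effect. Compound 1 `COC(=O)C1=C(C)N=C(C)/C(=C(\O)OC)C1c1ccccc1OC` gives 57.5 nM in this assay. Compound 2 `COC(=O)C1=C(C)N=C(C)/C(=C(/O)OC)C1c1cccc(Cl)c1` gives 15.9 nM, and compound 3 `COC(=O)C1=C(C)N=C(C)/C(=C(\O)OC)C1c1cc([N+](=O)[O-])ccc1O` gives 100 nM. Among these three numbers compound 1 stands second highest; its gap to compound 3 lies within the scatter of repeated measurements, while its gap to compound 2, the lowest of the three, lies beyond it.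

The step under consideration leads from compound 1 to compound 4 `C=Cc1ccccc1C1C(C(=O)OC)=C(C)N=C(C)/C1=C(\O)OC`, which is not yet measured. The change is vinyl in place of methoxy on an aromatic carbon. Within the data shown here, nothing among the measured compounds varies at this place of the ring, so no measured step speaks directly to it. The expectation is therefore for a modest move at most: the group that enters is counted at the same number of heavy atoms as the group that leaves, and the rest of the molecule is unchanged, so a step no larger than the scatter is expected in either direction. Compound 4 is thus estimated at 45 nM in this assay, within a range from 14 nM to 140 nM, which means an expected step of a 1.3-fold lower number from compound 1 to compound 4 (0.11 log units; within the scatter).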

Compound 4, half-maximal effective concentration: 4.47 nM
Estimate against measurement, compound 4: 10-fold (1.00 log units) above, and the stated range ends above it.
By their numbers in this assay, from the lowest: compound 4; then compound 2; then compounds 1 and 3 (each within the scatter of the next).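

Among these compounds, the measured change of vinyl in place of methoxy gives a 13-fold lower number from compound 1 to compound 4 (1.11 log units; beyond the scatter) in this assay, the first reading at this place on the aromatic ring, ortho to a large group. This place is therefore not indifferent to the exchange: the two groups are counted at the same number of heavy atoms, and neither has a ring or a net charge, yet the step is large. What differs in the count is that methoxy has an oxygen and a hydrogen-bond acceptor, whereas vinyl has neither and instead has a double bond outside aromatic rings, though no measurement here says why the step arises.

Going by these compounds, whether the step follows from the loss of the oxygen or from the presence of the double bond stays open, and an ethyl group at this place would help separate the two. Also open, on these data alone, is whether other groups at this place, such as an amine or a longer chain, would give a number close to that of the vinyl compound or to that of the methoxy compound.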